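Moving the halogen pattern on the aryl ketone of a chalcone

A few compounds are considered here, and "the series" means these few. Any claim that something is new, unique, unknown or untested is made for them only; others in the source may bear on it.

The three measured compounds share one core, a chalcone carrying a benzyloxy group on the styryl ring, and differ only in where a bromine sits on the phenyl attached to the carbonyl carbon. Compound 1 `O=C(/C=C/c1cccc(OCc2ccccc2)c1)c1ccccc1Br` gives 9100 nM in an ADME assay on CHO cells (Cricetulus griseus) for cytotoxicity, read by MTT assay, with a stated time of 68 h; a higher number here means a weaker inhibitor, a lower number a stronger inhibitor. Compound 2 `O=C(/C=C/c1cccc(OCc2ccccc2)c1)c1ccc(Br)cc1` gives 9000 nM, and compound 3 `O=C(/C=C/c1cccc(OCc2ccccc2)c1)c1cccc(Br)c1` gives 9200 nM. Compound 2 stands together with the other two: the steps of a 1.0-fold lower number from compound 1 to compound 2 (0.00 log units; within the scatter) and a 1.0-fold higher number from compound 2 to compound 3 (0.01 log units; within the scatter) are both within the scatter, as is a 1.0-fold higher number from compound 1 to compound 3 (0.00 log units; within the scatter), so no one of the three can be set apart from the others.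

Compound 4 `O=C(/C=C/c1cccc(OCc2ccccc2)c1)c1ccc(Cl)cc1Cl` is the unmeasured compound. Its change from compound 2 is 2,4-dichlorophenyl in place of 4-bromophenyl on a carbonyl carbon. The three measured steps all move a single bromine around the same ring and leave the number flat; none of them exchanges bromine for chlorine or adds a second halogen, so that part of the change is not covered by the data. On the flat steps seen so far, the expected step of no change at the digits printed from compound 2 to compound 4 (within the scatter) is none beyond the scatter, with a wider range to allow for the uncovered part of the change. Compound 4 is therefore estimated at 9000 nM in this assay, between 4000 nM and 20000 nM.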

Compound 4, half-maximal inhibitory concentration: 27500 nM
Beside the measured number, compound 4's estimate is 3.1-fold (0.49 log units) below it; measured number above the stated range.
By their numbers in this assay, from the lowest: compounds 2, 1 and 3 (each within the scatter of the next); then compound 4.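

In this assay the phenyl on the carbonyl carbon proves not to be indifferent to every change: the bromine's place on the ring left the number flat, yet the 2,4-dichlorophenyl group gives a 3.1-fold higher number from compound 2 to compound 4 (0.49 log units; beyond the scatter), and likewise a 3.0-fold higher number from compound 3 to compound 4 (0.48 log units; beyond the scatter) and a 3.0-fold higher number from compound 1 to compound 4 (0.48 log units; beyond the scatter). Compound 4 therefore stands apart as the weakest inhibitor of the four, so this position does respond to the halogen pattern, although the step is modest. The information available offers no explanation for this shift.

The change swaps bromine for chlorine and alters the number of halogens on the ring at once, so the compounds shown cannot tell which of the two carries the step, or whether both are needed; a 4-chlorophenyl or a 2,4-dibromophenyl group on the same core would separate them. Nor do they say how this position would answer to something other than a halogen on the ring, such as a methoxy group, an amine or a carboxylic acid.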